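2-Fluorophenyl in place of 4-chlorophenyl: working notes

The source may report more compounds than this note shows. Statements on the series, on what has been measured and on what is new or still open speak of the compounds shown alone.

In an ADME assay on MT4 cells (Homo sapiens) for cytotoxicity, read by MTT assay, with a stated time of 5 days (a higher number here means that more compound is tolerated, a lower number that less compound is tolerated), compound 1 `COc1cc2nc([S+]([O-])CC(=O)Nc3ccccc3[N+](=O)[O-])nc(Nc3c(Cl)cc(/C=C/C#N)cc3Cl)c2cc1OC` is reported only as a limit, > 199000 nM. Among the compounds with values here, compound 2 `COc1cc2nc([S+]([O-])CC(=O)Nc3ccc(Cl)cc3)nc(Nc3c(Cl)cc(/C=C/C#N)cc3Cl)c2cc1OC` gives 14400 nM, the only actual number so far. Compound 3 `COc1cc2nc([S+]([O-])CC(=O)Nc3ccccc3F)nc(Nc3c(Cl)cc(/C=C/C#N)cc3Cl)c2cc1OC` carries 2-fluorophenyl in place of 4-chlorophenyl on an amide-type nitrogen. Within the data shown here, the only measured step bearing on this, an at least 13-fold lower number from compound 1 to compound 2 (1.14 log units; beyond the scatter), is large and brought in the 4-chlorophenyl that now leaves, so a smaller step towards a higher number is expected in this assay. The size of that measured step rests on (the limit of > 199000 nM in this assay, at which 1 of the 2 values shown sits). The expected change is a 2.4-fold higher number from compound 2 to compound 3 (0.39 log units; beyond the scatter). For compound 3 the estimate is 35000 nM, with an expected range of 10000 nM to 130000 nM.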

Compound 3, half-maximal cytotoxic concentration: > 208000 nM
Compound 3 ended at the assay's limit; the forecaster's own chance of this, stated with the estimate: 15%; middle value at least 5.9-fold (0.77 log units) away from the limit.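

In this assay, 2-fluorophenyl on the amide-type nitrogen gives an at least 14-fold higher number from compound 2 to compound 3 (1.15 log units; beyond the scatter), so exchanging one halogen-bearing phenyl group for another is enough to produce a large step at this position. Compound 3 is reported only as a limit of the assay, so the size of that step is only a bound: the limit of > 208000 nM in this assay, at which 1 of the 3 values shown sits. Within the data shown here, compound 1 also stands at a limit, leaving 4-chlorophenyl as the only group here with an actual number, and the step from compound 1 to compound 3 cannot be read.

The compounds shown leave open how unsubstituted phenyl, 2-chlorophenyl and 4-fluorophenyl behave on this nitrogen. The effect of the halogen therefore cannot yet be separated from that of its ring position.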